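Swapping Benzyloxy for Propoxymethyl on the Shared Core

This account rests on a few compounds, and the source may have more. Where it says the series, first, only, none or still open, it means among the compounds named here.

Compound 1 `CN(C)c1cc2[nH]c(C3CCCCC3)nc2cc1NC(=O)c1ccc(Br)cc1` and compound 2 `CN(C)c1cc2[nH]c(C3CCCCC3)nc2cc1NC(=O)OCc1ccccc1` share a core and differ only at a carbonyl carbon, where compound 2 carries benzyloxy in place of 4-bromophenyl. In an ADME assay on Vero cells (Chlorocebus sabaeus) for cytotoxicity, read by resazurin assay, with a stated time of 3 days (on this read-out higher numbers stand for weaker inhibition and lower numbers for stronger inhibition), compound 1 gives > 100 ug/mL, which is a limit of the assay and not a number. In this assay compound 2 likewise gives > 100 ug/mL, again a limit. The step that the two limits leave unreadable from compound 1 to compound 2 therefore cannot be read. Both values sit at the limit of > 100 ug/mL in this assay, at which 2 of the 2 values shown sit, and no measured number on the shared core is known.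

Compound 3 `CCCOCC(=O)Nc1cc2nc(C3CCCCC3)[nH]c2cc1N(C)C` differs from compound 2 by propoxymethyl in place of benzyloxy on a carbonyl carbon. Within the data shown here, the only measured step, the one from compound 1 to compound 2, bears on this change insofar as it also replaces the group on the carbonyl carbon, but its size is hidden by the two limits, and no direction can be read from it. The expectation for compound 3 is therefore that this assay again reaches the limit, with an estimated step of a number no higher from compound 2 to compound 3 (the limit leaves the size open) that amounts to none beyond the scatter. Compound 3 is expected to give 100 ug/mL, with a range from 50 ug/mL to 200 ug/mL.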

Compound 3, half-maximal inhibitory concentration: < 50 ug/mL
Compound 3 ended at the assay's limit (the forecaster's own chance of this, stated with the estimate: 80%); middle value at least 2.0-fold (0.30 log units) from the limit.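

In this assay compound 3 gives < 50 ug/mL, which is a limit of the assay and not a number. Propoxymethyl in place of benzyloxy on the carbonyl carbon gives an at least 2.0-fold lower number from compound 2 to compound 3 (0.30 log units; that floor lies within the scatter), and propoxymethyl in place of 4-bromophenyl gives an at least 2.0-fold lower number from compound 1 to compound 3 (0.30 log units; that floor lies within the scatter). So this position, where the earlier pair showed nothing readable, can now be seen to bear on the read-out, and among the three compounds the only one that leaves the upper limit is the one whose group on the carbonyl carbon has no ring, although three compounds cannot separate the missing ring from the other differences between these groups.

As far as these compounds go, how far compound 3 actually lies from its limit, and so the true size of both steps, cannot be read, and the step from compound 1 to compound 2 stays unreadable as well: the limit of < 50 ug/mL in this assay, at which 1 of the 3 values shown sits. It also remains open whether a plain butyl chain, a longer ether chain, an amine or a carboxylic acid on the same carbonyl carbon would keep the number low or return it to the upper limit.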